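Ring swaps on the sulfur: compound 3 to compound 4

This account rests on a few compounds, and the source may have more. Where it says the series, first, only, none or still open, it means among the compounds named here.

Values in a functional assay on PC-3 cells (Homo sapiens) for antiproliferative activity, read by MTT assay, with a stated time of 72 h; a higher number here means a weaker inhibitor, a lower number a stronger inhibitor:
- compound 1 `C#CCSc1nc(Sc2nc(C)c(C)s2)c(C#N)c(-c2cc(OC)c(OC)c(OC)c2)n1`: > 20000 nM, a limit
- compound 2 `C#CCSc1nc(Sc2nncs2)c(C#N)c(-c2cc(OC)c(OC)c(OC)c2)n1`: 10300 nM
- compound 3 `C#CCSc1nc(Sc2nc[nH]n2)c(C#N)c(-c2cc(OC)c(OC)c(OC)c2)n1`: > 20000 nM, a limit

Compound 3 gives no number and sits at the limit of > 20000 nM in this assay, at which 2 of the 3 values shown sit. The next change leads to compound 4 `C#CCSc1nc(Sc2nc3ccccc3s2)c(C#N)c(-c2cc(OC)c(OC)c(OC)c2)n1`, 1,3-benzothiazol-2-yl in place of 1H-1,2,4-triazol-3-yl on a sulfur. Three measured swaps on that sulfur bear on it. These are an at least 1.9-fold lower number from compound 1 to compound 2 (0.28 log units; that floor lies within the scatter), an at least 1.9-fold higher number from compound 2 to compound 3 (0.28 log units; that floor lies within the scatter) and a step that the two limits leave unreadable from compound 1 to compound 3. None shows a size beyond the scatter, so no step beyond the scatter is expected in this assay, in either direction, and a further limit is quite possible. The expected step is an at least 1.1-fold lower number from compound 3 to compound 4 (0.04 log units; that floor lies within the scatter). Compound 4 is estimated at 18000 nM, within an expected range of 7000 nM to 40000 nM.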

Compound 4, half-maximal inhibitory concentration: > 20000 nM
Compound 4 was reported as a limit; the forecaster's own chance of this, stated with the estimate: 50%; middle value at least 1.1-fold (0.04 log units) from the limit.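

In this assay compound 4 gives > 20000 nM, a limit, so the fused 1,3-benzothiazol-2-yl on this sulfur also yields no number: the limit of > 20000 nM in this assay, at which 3 of the 4 values shown sit.

Among these compounds, the only readable step is an at least 1.9-fold higher number from compound 2 to compound 4 (0.28 log units; that floor lies within the scatter), and its floor stays within the scatter. The steps to compound 4 from compound 1 and compound 3 cannot be read, so these swaps on the sulfur still give no order beyond the scatter.

As far as these compounds go, whether a plain phenyl or pyridin-2-yl ring on this sulfur would give a number stays open. The same holds for an amine such as morpholine in place of the sulfur-linked ring.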